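A Halogen Swap on an Inactive Core

This account rests on a few compounds, and the source may have more. Where it says the series, first, only, none or still open, it means among the compounds named here.

Compound 1, `Cc1nc(N(C)C(=O)NC(=O)c2c(F)cccc2F)sc1C(=O)N/N=C/c1ccccc1Cl`, was tested in a functional assay on HepG2 cells (Homo sapiens) for inhibition, read by MTT assay, with a stated time of 72 h; on this read-out lower numbers stand for stronger inhibition and higher numbers for weaker inhibition. In this assay compound 1 gives > 100 ug/mL, which is a limit of the assay and not a number. Compound 2, `CNc1nc(C)c(C(=O)N/N=C/c2cc(C(F)(F)F)cc(C(F)(F)F)c2)s1`, shares the same core and was run in the same way. In this assay compound 2 gives > 100 ug/mL, again a limit rather than a number. Taken together, (the limit of > 100 ug/mL in this assay, at which 2 of the 2 values shown sit), so compound 1 stands at the same limit as the only other compound shown, with no measurable inhibition for either.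

Compound 3, `Cc1nc(N(C)C(=O)NC(=O)c2c(F)cccc2F)sc1C(=O)N/N=C/c1ccc(F)cc1`, has not yet been measured. It differs from compound 1 in one place: 4-fluorophenyl in place of 2-chlorophenyl on a carbon with a double bond to nitrogen. Among the compounds with values here, no step between two measured compounds is available to show how such a change moves this read-out. With both measured compounds at the limit, the expected step is a number no higher from compound 1 to compound 3 (the limit leaves the size open), none beyond the scatter. The estimate for compound 3 in this assay is 100 ug/mL, expected to fall between 40 ug/mL and 250 ug/mL, and most likely to be reported again only as a limit.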

Compound 3, half-maximal inhibitory concentration: > 100 ug/mL
Compound 3 was reported as a limit; the forecaster's own chance of this, stated with the estimate: 80%; the middle value sits exactly at the limit.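

Compound 1 and compound 3 are each reported only as a limit, so putting 4-fluorophenyl in place of 2-chlorophenyl gives no step that can be read in this assay: the limit of > 100 ug/mL in this assay, at which 3 of the 3 values shown sit.

The compounds shown leave open which structures on this shared core, if any, give inhibition strong enough to be measured as an actual number.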